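Changing the Ester Side Chain Before the Next Measurement

The source may hold more compounds than are shown below. What is called first, only, known or untested is meant among the compounds shown, and "the series" means these compounds.

Three compounds have been measured in an assay on isolated protein for inhibition of protein kinase C zeta type (Homo sapiens), with stated times of 1 h and 2.5 min, tested at 30 uM; on this read-out lower numbers stand for less inhibition and higher numbers for more inhibition at the one concentration tested (going by the name of the read-out):

Compound 1, `CCOC(=O)c1cscc1-c1ccc(OC)c(OC)c1`: 3%
Compound 2, `CCOC(=O)c1c(-c2ccc(OC)c(OC)c2)csc1NC(N)=O`: 14%
Compound 3, `COc1ccc(-c2csc(N)c2C(=O)OCc2cccc(C)c2)cc1OC`: 67%

Compound 3 stands highest of the three numbers in this assay; its nearest neighbour is compound 2, and compound 1 lies furthest below it, both gaps being beyond the usual scatter. Going by the values given here, the one step between compounds that differ in a single place is a number 11 percentage points higher from compound 1 to compound 2 (beyond the scatter), which concerns a ureido in place of hydrogen on an aromatic carbon.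

Compound 4, `COc1ccc(-c2csc(N)c2C(=O)OCc2ccc(C#N)cc2)cc1OC`, is the next compound to be measured. It differs from compound 3 as follows: 4-cyanophenyl in place of 3-methylphenyl on a saturated chain carbon bound to an oxygen next to a carbonyl group. Among the compounds with values here, no measured pair differs at this place, so the step from compound 1 to compound 2 does not bear on it, and nothing measured here tells how a change on the saturated chain carbon bound to an oxygen next to a carbonyl group affects this assay. The expectation therefore rests on compound 3 alone: compound 4 is expected to land near it, with a step of a number 12 percentage points lower from compound 3 to compound 4 (beyond the scatter) that may well lie within the scatter. Compound 4 is thus estimated at 55%, in a range from 25% to 80%.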

Compound 4, a percentage reported as inhibition, at one concentration (the size of the read-out at that concentration, not a potency): 10%
Compound 4: the middle estimate sits 45 percentage points above what was measured, and the stated range ends above it.
By their numbers in this assay, from the lowest: compounds 1, 4 and 2 (each within the scatter of the next, the first and the last beyond it); then compound 3.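

In this assay the swap of 4-cyanophenyl for 3-methylphenyl gives a number 57 percentage points lower from compound 3 to compound 4 (beyond the scatter) and marks the saturated chain carbon bound to an oxygen next to a carbonyl group as a place where a small edit can count heavily. Both groups hold one six-membered aromatic ring of carbon only, so having that ring at this place is not enough to keep the high number of compound 3. Nothing measured here explains the fall.

The step changes the substituent and its numbered place on the ring together, so the two changes cannot be told apart. A 4-methylbenzyl or a 3-cyanobenzyl group would separate them, and a carboxylic acid in place of the ester would test whether the ring is needed at all.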